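The source may report more compounds than this note shows. Statements on the series, on what has been measured and on what is new or still open speak of the compounds shown alone.

Measured so far:
compound 1, `CC[C@@H](Nc1c(C#N)c(-c2ccc(-c3cccc(Cl)c3OC)cc2)nc2cnccc12)C(N)=O`: 3.1
compound 2, `CCCCC(Nc1c(C#N)c(-c2ccc(-c3ccccc3OCC)cc2)nc2cnccc12)C(N)=O`: 3.6

In a physicochemical assay for lipophilicity, read by HPLC, at pH 7.5 (on this read-out lower numbers stand for lower lipophilicity and higher numbers for higher lipophilicity), compound 1 gives 3.1, the lower of the two numbers in hand; compound 2 gives 3.6, a higher reading, and the gap between the two lies beyond the usual scatter. Going by the values given here, no pair of measured compounds differs in a single place, so the series offers no measured single-change step as a guide.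

Compound 3, `CC[C@@H](Nc1c(C#N)c(-c2ccc(-c3ccccc3OC)cc2)nc2cnccc12)C(N)=O`, has not yet been measured in this assay. It differs from compound 1 by hydrogen in place of chloro on an aromatic carbon, that is, the 3-chloro-2-methoxyphenyl of compound 1 reads as 2-methoxyphenyl in compound 3; donors, acceptors and charge are unchanged. For compound 3 a downward step in this assay, beyond the scatter, is expected. The estimated step is a number 0.60 log units lower from compound 1 to compound 3 (beyond the scatter). Compound 3 is accordingly expected to give 2.5 in this assay, within a range of 2.1 to 2.9.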

Compound 3, distribution coefficient: 2.7
Compound 3: middle estimate off by 0.20 log units, on the low side, and the stated range covers the measured number.
By their numbers in this assay, from the lowest: compound 3; then compound 1; then compound 2.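

In this assay, going by these compounds alone, the step from 3-chloro-2-methoxyphenyl to 2-methoxyphenyl is the first single-place change the series can read: a number 0.40 log units lower from compound 1 to compound 3 (beyond the scatter) stands beyond the scatter. The aromatic carbon ortho to a methoxy group and meta to a large group is therefore a place where this read-out responds to a change of substituent. The change here is small in count, one chlorine as the only heavy atom lost, with no hydrogen-bond donor, acceptor or net charge involved.

Open, going by these compounds, is what an amine, a carboxylic acid or a fluoro group on this carbon would read, and whether the step holds in the setting of compound 2, which carries other differences. Nothing at hand gives a reason for the size of this step.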